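Trifluoromethyl for bromo in a series read only as limits

The source may report more compounds than this note shows. Statements on the series, on what has been measured and on what is new or still open speak of the compounds shown alone.

Of the compounds shown here, three sharing one core have been tested in a physicochemical assay for solubility, in phosphate buffer, measured as kinetic solubility, at pH 7.4 (a higher number here means a more soluble compound, a lower number a less soluble compound), and none has returned a number. Compound 1 (`Cc1oc(-c2ccccc2Cl)nc1CN1CCC(C(=O)NCCCN2C[C@H](C)C[C@H](C)C2)CC1`) gives > 72 ug/mL as a limit. Compound 2 (`Cc1oc(-c2c(Cl)cccc2Cl)nc1CN1CCC(C(=O)NCCCN2C[C@H](C)C[C@H](C)C2)CC1`) gives > 77 ug/mL as a limit too. Compound 3 (`Cc1oc(-c2c(Cl)cccc2Br)nc1CN1CCC(C(=O)NCCCN2C[C@H](C)C[C@H](C)C2)CC1`) gives > 83 ug/mL as a limit as well, so that limit is all that places it.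

Compound 4 (`Cc1oc(-c2c(Cl)cccc2C(F)(F)F)nc1CN1CCC(C(=O)NCCCN2C[C@H](C)C[C@H](C)C2)CC1`) differs from compound 3 in one place: trifluoromethyl in place of bromo on an aromatic carbon with trifluoromethyl in place of bromo on an aromatic carbon, ortho to a large group and meta to a chloro group.

Among the measured compounds shown here, no measured step makes this same exchange. The closest is bromo in place of chloro, a step that the two limits leave unreadable from compound 2 to compound 3 and the other two are a step that the two limits leave unreadable from compound 1 to compound 2 and a step that the two limits leave unreadable from compound 1 to compound 3 in turn. None of them offers a size, so the expectation rests on the limits alone. For the measured compounds named here, every compound so far has ended at a limit, so no step beyond the scatter is expected in this assay and the estimated change is an at least 1.0-fold lower number from compound 3 to compound 4 (0.00 log units; that floor lies within the scatter) with another limit the likely report. Compound 4 is estimated at 82 ug/mL with an expected range from 50 ug/mL to 90 ug/mL as its span.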

Compound 4, solubility: 65.1 ug/mL
Compound 4: middle estimate off by 1.3-fold (0.10 log units), on the high side, and the stated range covers the measured number.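

Among the compounds shown here, with trifluoromethyl on this aromatic carbon, ortho to a large group and meta to a chloro group, compound 4 is the first compound to return a number rather than a limit in this assay. The new steps are an at least 1.2-fold lower number from compound 3 to compound 4 (0.10 log units; that floor lies within the scatter), an at least 1.1-fold lower number from compound 2 to compound 4 (0.07 log units; that floor lies within the scatter) and an at least 1.1-fold lower number from compound 1 to compound 4 (0.04 log units; that floor lies within the scatter), so the exchange for bromo, chloro or hydrogen gives only floors, and none of them goes beyond the scatter. These steps are floors and not sizes because compound 3 stands only at a limit, the nearest case of the three: the limit of > 83 ug/mL in this assay, at which 1 of the 4 values shown sits.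

As far as these compounds go, the steps among compounds 1, 2 and 3 cannot be read, so it remains open how far any of these three truly lies from compound 4 and whether the 2-chloro-6-(trifluoromethyl)phenyl group differs from the 2-bromo-6-chlorophenyl group at all in this assay. Also open, from the compounds shown here alone, is how a nitrile, a methoxy group or an amine at this same position would read there, and whether any such group would return a number rather than a limit.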